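Swapping a Chlorophenyl for a Pyrimidinyl Ring

The compounds below may be only part of what the source reports. "The series", "measured", "known", "first", "only" and "open" are said of these compounds alone.

Of the compounds shown here, three built on one shared core have been tested in an ADME assay on MT4 cells (Homo sapiens) for cytotoxicity, read by MTT assay, with a stated time of 5 days; on this read-out lower numbers stand for higher toxicity in this test and higher numbers for lower toxicity in this test. Compound 1 `Cc1cc(C#N)cc(C)c1Oc1nc(Nc2ccc(C#N)cc2)ncc1-c1ccccc1` gives 31800 nM, compound 2 `Cc1ccc(-c2cnc(Nc3ccc(C#N)cc3)nc2Oc2c(C)cc(C#N)cc2C)cc1` gives 26100 nM, and compound 3 `Cc1cc(C#N)cc(C)c1Oc1nc(Nc2ccc(C#N)cc2)ncc1-c1ccc(Cl)cc1` gives 72600 nM, the highest number of the three. The steps leading to it were a 2.3-fold higher number from compound 1 to compound 3 (0.36 log units; beyond the scatter) and a 2.8-fold higher number from compound 2 to compound 3 (0.44 log units; beyond the scatter), while between the other two the change was a 1.2-fold lower number from compound 1 to compound 2 (0.09 log units; within the scatter). Compound 4 `Cc1cc(C#N)cc(C)c1Oc1nc(Nc2ccc(C#N)cc2)ncc1-c1cncnc1` differs from compound 3 by pyrimidin-5-yl in place of 4-chlorophenyl on an aromatic carbon. Going by the values given here, no measured step exchanges a whole ring, so the modest shifts seen on this ring are the only guide in this assay. The expected step is a 1.8-fold lower number from compound 3 to compound 4 (0.26 log units; within the scatter), toward a lower number. Compound 4 is therefore estimated at 40000 nM, between 15000 nM and 100000 nM.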

Compound 4, half-maximal cytotoxic concentration: > 298000 nM
Compound 4 gave a limit, no number; the forecaster's own chance of this, stated with the estimate: 25%; middle value at least 7.4-fold (0.87 log units) away from the limit.
By their numbers in this assay, from the lowest: compounds 2 and 1 (each within the scatter of the next); then compound 3. At a limit, above all of these: compound 4.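

In this assay compound 4 gives only a limit, not a number: the limit of > 298000 nM in this assay, at which 1 of the 4 values shown sits. Exchanging the whole ring at this position moves the read-out further than chloro or methyl on the phenyl ring did, with an at least 4.1-fold higher number from compound 3 to compound 4 (0.61 log units; beyond the scatter), an at least 9.3-fold higher number from compound 1 to compound 4 (0.97 log units; beyond the scatter) and an at least 11-fold higher number from compound 2 to compound 4 (1.05 log units; beyond the scatter). All three steps run toward lower toxicity in this test, so pyrimidin-5-yl separates from the three carbon-only rings. On these data alone, the true size of these steps stays unknown, as compound 4 has no exact number. As far as these compounds go, whether a pyridinyl or morpholinyl group here would shift the read-out as far also remains open.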